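The source may hold more compounds than are shown below. What is called first, only, known or untested is meant among the compounds shown, and "the series" means these compounds.

Compound 1 `O=C(CCCCC1CCSS1)Nc1ccc(Cl)cn1`: 33.7%
Compound 2 `O=C(CCCCC1CCSS1)Nc1ccc(Br)cn1`: 38%
Compound 3 `O=C(CCCCC(S)CCS)Nc1ccc(Cl)cn1`: not yet measured

Among the compounds with values here, in a functional assay on NCI-H460 cells (Homo sapiens) for inhibition, read by MTT assay, with a stated time of 24 h, tested at 10 ug/mL (a lower number here means less inhibition of growth, a higher number more inhibition of growth at the concentration tested), compound 1 gives 33.7% and compound 2 gives 38%, so compound 1 stands level with the only other measured compound: a number 4.3 percentage points higher from compound 1 to compound 2 (within the scatter). That step, bromo in place of chloro on an aromatic carbon, is the only one measured. It does not touch the group that changes in compound 3: a group of 5 heavy atoms (3 carbon, 2 sulfur; no ring) in place of a group of 5 heavy atoms (3 carbon, 2 sulfur; one five-membered non-aromatic ring with 2 hetero atoms), on a saturated chain carbon, four bonds along the chain from a carbonyl carbon. No measurement therefore shows what this change does, and no step beyond the scatter can be forecast. The expected step is a number 1.3 percentage points higher from compound 1 to compound 3 (within the scatter). In this assay the estimate for compound 3 is 35%, within a wide range from 18% to 55%.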

Compound 3, percent growth inhibition at one concentration: 27.4%
Compound 3: the middle estimate sits 7.6 percentage points above what was measured; the range from low to high includes it.
By their numbers in this assay, from the lowest: compounds 3, 1 and 2 (each within the scatter of the next, the first and the last beyond it).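

At this position, on a saturated chain carbon, four bonds along the chain from a carbonyl carbon, 1,3-disulfanylpropyl replaces the group with the five-membered non-aromatic ring, and in this assay the result is a number 6.3 percentage points lower from compound 1 to compound 3 (within the scatter). Growth inhibition at the concentration tested therefore stays level when this ring is opened. No further data bear on this result. Still open, on these data alone, is whether a different group here, such as a carboxylic acid or an amine, would give a step beyond the scatter. Also open, as far as these compounds go, is whether the open chain behaves the same with bromo in place of chloro.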